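A few compounds are considered here, and "the series" means these few. Any claim that something is new, unique, unknown or untested is made for them only; others in the source may bear on it.

In a functional assay on A549 cells (Homo sapiens) for antiproliferative activity, read by MTT assay, with a stated time of 48 h (a lower number here means a stronger inhibitor, a higher number a weaker inhibitor), compound 1 `O=C(N[C@H]1C[C@@H](C(=O)NO)N(S(=O)(=O)c2ccc(Oc3ccccc3)cc2)C1)c1cccc2no[n+]([O-])c12` gives 21500 nM. Compound 2 `COc1ccc(/C=C/C(=O)N2C[C@@H](NC(=O)c3ccc4no[n+]([O-])c4c3)C[C@H]2C(=O)NO)cc1OC` gives 13200 nM in this assay, and the two numbers sit within the scatter of each other, so neither compound can be set apart from the other. Compound 3 `COc1ccc(/C=C/C(=O)N2C[C@@H](NC(=O)c3cccc4no[n+]([O-])c34)C[C@H]2C(=O)NO)cc1OC` differs from compound 2 by a group of 10 heavy atoms (6 carbon, 2 nitrogen, 2 oxygen; one five-membered aromatic ring with 3 hetero atoms, one six-membered aromatic ring of carbon only) in place of a group of 10 heavy atoms (6 carbon, 2 nitrogen, 2 oxygen; one five-membered aromatic ring with 3 hetero atoms, one six-membered aromatic ring of carbon only), on a carbonyl carbon. Among the measured compounds shown here, with no measured step of this kind to lean on, only a small change is expected, a 1.0-fold lower number from compound 2 to compound 3 (0.01 log units; within the scatter), in no particular direction beyond the scatter. Compound 3 is therefore estimated at 13000 nM in this assay, within a range from 6000 nM to 28000 nM.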

Compound 3, half-maximal inhibitory concentration: 25600 nM
For compound 3 the middle estimate is 2.0-fold (0.29 log units) below the measured one, and the stated range covers the measured number.
By their numbers in this assay, from the lowest: compounds 2, 1 and 3 (each within the scatter of the next).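

In this assay the first pair shown to differ in one place, on a carbonyl carbon whose other neighbour is an amide-type nitrogen, gives a 1.9-fold higher number from compound 2 to compound 3 (0.29 log units; within the scatter) and so cannot be set apart. Rejoining the same atoms within this group therefore shows no readable effect at this position in these two compounds. No measurement shown bears on the reason for these numbers. The compounds shown leave open how a plain phenyl group on this carbonyl carbon, or an amine in that group, would read in this assay and whether either would stand beyond the scatter.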